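This account rests on a few compounds, and the source may have more. Where it says the series, first, only, none or still open, it means among the compounds named here.

Compound 1 `COc1cc(O)cc(O)c1C(=O)/C=C/c1ccc(O)cc1` and compound 2 `COc1cc(O)cc(O)c1C(=O)/C=C/c1ccc(Cl)cc1` share one core and differ only at the aromatic carbon of the second ring. In a functional assay on A549 cells (Homo sapiens) for inhibition, read by MTT assay, with a stated time of 72 h (a lower number here means a stronger inhibitor, a higher number a weaker inhibitor), compound 1 reaches only the limit of the measurement, > 50000 nM. Compound 1 thus sits at the limit (the limit of > 50000 nM in this assay, at which 1 of the 2 values shown sits). In this assay, going by the values given here, compound 2 gives 18200 nM, the single number so far. Among the compounds with values here, the step of an at least 2.7-fold lower number from compound 1 to compound 2 (0.43 log units; beyond the scatter) is the only measured change, and it starts from a limit, so its true size is unknown. Compound 3 `COc1cc(O)cc(O)c1C(=O)/C=C/c1ccc([N+](=O)[O-])cc1` is not yet measured; it differs from compound 2 in that (nitro in place of chloro on an aromatic carbon). Within the data shown here, no measured step joins two numbers, and none concerns nitro, so no direction can be read from the series for this change. Compound 3 is therefore expected near compound 2, an estimated 16000 nM (range 5500 nM to 48000 nM), a step of a 1.1-fold lower number from compound 2 to compound 3 (0.06 log units; within the scatter) expected within the scatter.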

Compound 3, half-maximal inhibitory concentration: > 50000 nM
Compound 3: no number, only a limit (the forecaster's own chance of this, stated with the estimate: 20%); middle value at least 3.1-fold (0.49 log units) from the limit.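

Nitro in place of chloro at this aromatic carbon, para to a large group, gives an at least 2.7-fold higher number from compound 2 to compound 3 (0.43 log units; beyond the scatter) in this assay, the first measured step that leaves chloro rather than reaching it. Chloro is thus the only one of the three groups at this position that gives a number rather than a limit, and a limit now marks most of the series: the limit of > 50000 nM in this assay, at which 2 of the 3 values shown sit. The step between the hydroxy and nitro compounds cannot be read, so these two groups cannot be ordered.

Still open, as far as these compounds go, is whether any other group at this carbon, such as bromo, methyl or an amine, gives a lower number than chloro in this assay. Also open, from the compounds shown here alone, is how far the hydroxy and methoxy groups of the shared core contribute to the number seen with chloro.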